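The compounds below may be only part of what the source reports. "The series", "measured", "known", "first", "only" and "open" are said of these compounds alone.

For the measured compounds named here, compound 2 `Cc1ccc(NC2=CC(=O)c3nc4n(c3C2=O)[C@H]2OC[C@@H](O)[C@H]2OC4)cc1` is the only compound here with an exact number: in a functional assay on ECa-109 cells for inhibition, with ECa-109 cell line (Homo sapiens) as the target, read by sulforhodamine B assay (on this read-out lower numbers stand for stronger inhibition and higher numbers for weaker inhibition), compound 2 gives 3480 nM. Compound 1 `COc1ccc(NC2=CC(=O)c3nc4n(c3C2=O)[C@H]2OC[C@@H](O)[C@H]2OC4)cc1` reached only a limit of the assay, > 4000 nM. Going by the values given here, the one measured step is therefore bounded by that limit (the limit of > 4000 nM in this assay, at which 1 of the 2 values shown sits). Compound 3 `COc1cccc(NC2=CC(=O)c3nc4n(c3C2=O)[C@H]2OC[C@@H](O)[C@H]2OC4)c1` differs from compound 2 by 3-methoxyphenyl in place of 4-methylphenyl on an amine nitrogen. Among the compounds with values here, because the only related step, an at least 1.1-fold lower number from compound 1 to compound 2 (0.06 log units; that floor lies within the scatter), lay within the scatter, no move beyond the scatter is expected for compound 3 in this assay, and the step of a 1.1-fold higher number from compound 2 to compound 3 (0.06 log units; within the scatter) is the estimate. Compound 3 is expected near 4000 nM, between 1500 nM and 12000 nM.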

Compound 3, half-maximal inhibitory concentration: 7620 nM
Beside the measured number, compound 3's estimate is 1.9-fold (0.28 log units) below it; measured number inside the range.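

For the compounds shown here, the group on the amine nitrogen does affect the read-out in this assay: 3-methoxyphenyl in place of 4-methylphenyl gives a 2.2-fold higher number from compound 2 to compound 3 (0.34 log units; beyond the scatter), the first step here beyond the scatter, toward weaker inhibition. This step is modest, and it changes both the substituent and its place on the ring, so neither can be credited alone.

Going by these compounds, compound 1 stands at a limit, so its step to compound 3 cannot be read: the limit of > 4000 nM in this assay, at which 1 of the 3 values shown sits. Also open is how a 4-aminophenyl or 3-carboxyphenyl group would behave on this nitrogen.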